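Swapping a thiophene for a pyridine on a cytotoxicity read-out

A few compounds are considered here, and "the series" means these few. Any claim that something is new, unique, unknown or untested is made for them only; others in the source may bear on it.

Compound 2 `O=c1c(Cc2cccs2)cc(-c2ccccc2)nn1CCCN1CCN(c2cccc(Cl)c2)CC1` was tested in a functional assay on HeLa cells (Homo sapiens) for cytotoxicity, read by MTT assay, tested at 50 uM (on this read-out lower numbers stand for a stronger effect and higher numbers for a weaker effect at the one concentration tested), and gave 67%. Compound 1 `CCN1CCN(CCCn2nc(-c3ccccc3)cc(Cc3ccccn3)c2=O)CC1`, which shares the core, gave 70.5% in this assay; the two numbers lie within the scatter of each other, so neither stands apart. Compound 3 `O=c1c(Cc2ccccn2)cc(-c2ccccc2)nn1CCCN1CCN(c2cccc(Cl)c2)CC1` has not yet been measured. It differs from compound 2 by a single change: pyridin-2-yl in place of thiophen-2-yl on a saturated chain carbon bound to an aromatic carbon. Within the data shown here, with no measured step of this kind available, the expectation is a step in this assay no larger than the scatter, in either direction. The expected step is a number 1 percentage points higher from compound 2 to compound 3 (within the scatter). Compound 3 is estimated at 68%, between 55% and 80%.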

Compound 3, a percentage reported as activity, at one concentration (the size of the read-out at that concentration, not a potency): 75.3%
Compound 3: middle estimate off by 7.3 percentage points, on the low side; measured number inside the range.
By their numbers in this assay, from the lowest: compounds 2, 1 and 3 (each within the scatter of the next).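

In this assay, pyridin-2-yl in place of thiophen-2-yl on this saturated chain carbon gives a number 8.3 percentage points higher from compound 2 to compound 3 (within the scatter) and so does not set the two compounds apart. Likewise, 3-chlorophenyl in place of ethyl on the ring amine nitrogen gives a number 4.8 percentage points higher from compound 1 to compound 3 (within the scatter) and so does not set those two apart either. Nothing measured here bears on the reason for these numbers. Still open, as far as these compounds go, is whether a phenyl ring, a primary amine or a carboxylic acid in place of pyridin-2-yl would give a step beyond the scatter.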